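This account rests on a few compounds, and the source may have more. Where it says the series, first, only, none or still open, it means among the compounds named here.

Of the compounds shown here, three with a shared core have been measured in an assay on cells for inhibition of MAP kinase-interacting serine/threonine-protein kinase 1 (Homo sapiens), read by mobility shift assay, with stated times of 10 min and 60 min, in the presence of a further agent that is not named here; on this read-out lower numbers stand for stronger inhibition and higher numbers for weaker inhibition. Compound 1 `NC(=O)c1ccc(-c2cccnc2)cc1Cl` gives 11000 nM, compound 2 `CCNc1cc(-c2cccnc2)ccc1C(N)=O` gives 58000 nM, and compound 3 `NC(=O)c1ccc(-c2cccnc2)cc1OC1CCNCC1` gives 1100 nM, the lowest of the three numbers and thus the strongest inhibitor among them. The next compound, compound 4 `CC(C)Oc1cc(-c2cccnc2)ccc1C(N)=O`, differs from compound 3 in one place: isopropyl in place of piperidin-4-yl on an oxygen on an aromatic ring. For the measured compounds named here, no measured step removes the piperidin-4-yl group itself, so the bearing evidence is indirect: the piperidin-4-yl)oxy group brought a 10-fold lower number from compound 1 to compound 3 (1.00 log units; beyond the scatter) and a 53-fold lower number from compound 2 to compound 3 (1.72 log units; beyond the scatter), so its replacement by a smaller group without a ring is expected to move the number back upward, beyond the scatter. The estimate for compound 4 is therefore 5000 nM, within 1500 nM to 20000 nM, meaning an expected 4.5-fold higher number from compound 3 to compound 4 (0.66 log units; beyond the scatter).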

Compound 4, half-maximal inhibitory concentration: 880 nM
Beside the measured number, compound 4's estimate is 5.7-fold (0.75 log units) above it, and the stated range ends above it.
By their numbers in this assay, from the lowest: compounds 4 and 3 (each within the scatter of the next); then compound 1; then compound 2.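

In this assay, the piperidin-4-yl group on this oxygen can give way to isopropyl, a smaller group without a ring or nitrogen, with no change beyond the scatter (a 1.3-fold lower number from compound 3 to compound 4 (0.10 log units; within the scatter)). The advantage of this position's ether groups therefore does not rest on that ring: isopropoxy in place of chloro gives a 13-fold lower number from compound 1 to compound 4 (1.10 log units; beyond the scatter), and isopropoxy in place of ethylamino gives a 66-fold lower number from compound 2 to compound 4 (1.82 log units; beyond the scatter). No measurement here explains these differences.

Going by these compounds, what a smaller methoxy group or a longer butoxy chain would give on this oxygen remains open. So does the effect of a carboxylic acid at the end of such a chain.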